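This account rests on a few compounds, and the source may have more. Where it says the series, first, only, none or still open, it means among the compounds named here.

Measured so far in an assay on COS-7 cells for displacement of a labelled ligand from Endothelin receptor type B (Sus scrofa); a lower number here means a stronger inhibitor, a higher number a weaker inhibitor:

- compound 1 `COC(=O)CCCc1onc(NS(=O)(=O)c2ccc(C(C)(C)C)cc2)c1Sc1cccc(OC)c1`: 310 nM
- compound 2 `COc1cccc(Sc2c(NS(=O)(=O)c3ccc(C(C)(C)C)cc3)noc2CCCC(=O)O)c1`: 500 nM
- compound 3 `COc1cccc(Sc2c(NS(=O)(=O)c3ccc(C(C)(C)C)cc3)noc2CO)c1`: 560 nM

Compound 3 carries the highest of the three numbers, but its nearest neighbour is compound 2, a 1.1-fold higher number from compound 2 to compound 3 (0.05 log units; within the scatter), and the furthest is compound 1, a 1.8-fold higher number from compound 1 to compound 3 (0.26 log units; within the scatter); neither gap is beyond the scatter, so the three compounds cannot be ranked against each other on these numbers.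

Compound 4 `COc1cccc(Sc2c(NS(=O)(=O)c3ccc(C(C)(C)C)cc3)noc2C)c1` differs from compound 3 in one place: hydrogen in place of hydroxy on a saturated chain carbon bound to an aromatic carbon.

Going by the values given here, the steps that bear on this change are the two that alter the same saturated chain carbon bound to an aromatic carbon. Replacing 2-(methoxycarbonyl)ethyl by hydroxy gave a 1.8-fold higher number from compound 1 to compound 3 (0.26 log units; within the scatter), and replacing 2-carboxyethyl by hydroxy gave a 1.1-fold higher number from compound 2 to compound 3 (0.05 log units; within the scatter). Both were within the scatter, and the step from compound 1 to compound 2, a 1.6-fold higher number from compound 1 to compound 2 (0.21 log units; within the scatter), was likewise small. Three substituents of quite different size at this position gave numbers that cannot be told apart, so removing the hydroxy altogether is expected to leave the number close to that of compound 3. Compound 4 is therefore estimated at 600 nM in this assay, within a range of 250 nM to 1500 nM, which means an expected step of a 1.1-fold higher number from compound 3 to compound 4 (0.03 log units; within the scatter), no larger than the scatter.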

Compound 4, half-maximal inhibitory concentration: 300 nM
Compound 4: the middle estimate sits 2.0-fold (0.30 log units) above what was measured, and the stated range covers the measured number.
By their numbers in this assay, from the lowest: compounds 4, 1, 2 and 3 (each within the scatter of the next).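

With hydrogen in place of hydroxy on a saturated chain carbon bound to an aromatic carbon, this assay gives a 1.9-fold lower number from compound 3 to compound 4 (0.27 log units; within the scatter), so the hydroxy oxygen can go without a step beyond the scatter. Against the two longer substituents the picture is the same, with a 1.7-fold lower number from compound 2 to compound 4 (0.22 log units; within the scatter) for 2-carboxyethyl and a 1.0-fold lower number from compound 1 to compound 4 (0.01 log units; within the scatter) for 2-(methoxycarbonyl)ethyl, so across compounds 1 to 4 no substituent at this place separates from the others. No measurement shown gives a reason for this flatness.

On these data alone, whether an amine, an amide or a purely hydrocarbon longer chain at this carbon would produce a step beyond the scatter remains open. Also open, as far as these compounds go, is whether this flatness holds with another group in place of the 3-methoxyphenyl thioether of the shared core.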